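The source may hold more compounds than are shown below. What is called first, only, known or untested is meant among the compounds shown, and "the series" means these compounds.

The measured compounds and their values in cells:

compound 1, `CC(C)=CCC/C(C)=C/CC1Cc2c(O)cc(=O)n(CCCO)c2CC1(C)C`: 0%
compound 2, `CC(C)=CCC/C(C)=C/CC1Cc2c(OC(=O)Nc3ccc(F)cc3)cc(=O)n(CCCO)c2CC1(C)C`: 6.2%
compound 3, `CC(C)=CCC/C(C)=C/CC1Cc2c(OC(=O)Nc3ccccc3F)cc(=O)n(CCCO)c2CC1(C)C`: 0%

In a functional assay on PANC-1 cells (Homo sapiens) for inhibition, read by MTT assay, with a stated time of 24 h, tested at 10 uM (a higher number here means more inhibition at the concentration tested (going by the name of the read-out), a lower number less inhibition), compound 1 gives 0%. Compound 2 gives 6.2% and compound 3 gives 0%. Compound 3 stands level with compound 1, and its separation from compound 2 is a number 6.2 percentage points lower from compound 2 to compound 3 (within the scatter), so all three numbers sit within the usual scatter of one another.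

Compound 4, `CC(C)=CCC/C(C)=C/CC1Cc2c(OC(=O)Nc3cccc(C(F)(F)F)c3)cc(=O)n(CCCO)c2CC1(C)C`, differs from compound 3 in one place: 3-(trifluoromethyl)phenyl in place of 2-fluorophenyl on an amide-type nitrogen.

For the measured compounds named here, two measured steps bear on this change. Putting a (4-fluorophenyl)carbamoyl group onto the oxygen gave a number 6.2 percentage points higher from compound 1 to compound 2 (within the scatter), and the (2-fluorophenyl)carbamoyl group gave no change at the digits printed from compound 1 to compound 3 (within the scatter); swapping the ring on the amide-type nitrogen gave a number 6.2 percentage points lower from compound 2 to compound 3 (within the scatter). None of these moves beyond the scatter, so a third ring on the same nitrogen is expected to leave the read-out where it is: the expected step is a number 3 percentage points higher from compound 3 to compound 4 (within the scatter). Compound 4 is therefore estimated at 3%, with a range from 0% to 15%.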

Compound 4, a percentage reported as inhibition, at one concentration (the size of the read-out at that concentration, not a potency): 6.7%
Compound 4: the middle estimate sits 3.7 percentage points below what was measured; measured number inside the range.
By their numbers in this assay, from the lowest: compounds 1, 3, 2 and 4 (each within the scatter of the next).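

Placing 3-(trifluoromethyl)phenyl on the amide-type nitrogen instead of 2-fluorophenyl, with 10 heavy atoms entering where 7 leave, gives a number 6.7 percentage points higher from compound 3 to compound 4 (within the scatter) in this assay. Put in place of 4-fluorophenyl, the same group gives a number 0.5 percentage points higher from compound 2 to compound 4 (within the scatter), so all three fluorinated phenyl rings on this nitrogen now read alike, and the bigger group does not carry the read-out beyond the scatter. Nothing available explains this result.

The compounds shown leave open whether a group of another kind on this nitrogen, such as a longer alkyl chain or a phenyl ring bearing an amine or a carboxylic acid, would separate from these numbers. With a single tested concentration, they also leave open how any of these compounds would behave at higher concentrations.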